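Cyano in Place of Methoxy on a Receptor Ligand Core

The compounds below may be only part of what the source reports. "The series", "measured", "known", "first", "only" and "open" are said of these compounds alone.

Of the compounds shown here, two have so far been measured in an assay on CHO cells for displacement of a labelled ligand from corticotropin-releasing factor receptor 1 (Homo sapiens), read by scintillation counting, with a stated time of 1.5 h; on this read-out higher numbers stand for weaker inhibition and lower numbers for stronger inhibition. Compound 1 `CCN(CC)c1ccc(OC)c2nc(Nc3c(C)cc(Cl)cc3OC)n(C)c12` gives 13 nM. Compound 2 `CCCN(CCC)c1cccc2nc(Nc3c(C)cc(C)cc3C)sc12`, built on a different core, gives 77 nM. Compound 1 therefore stands with the lower of the two numbers, and its gap to compound 2 lies beyond the scatter. Since the two compounds differ in more than one place, no single change between them can be traced.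

Compound 3 `CCN(CC)c1ccc(C#N)c2nc(Nc3c(C)cc(Cl)cc3OC)n(C)c12` has not yet been measured. It differs from compound 1 in one place: cyano in place of methoxy on an aromatic carbon. The group sits on the six-membered aromatic ring of carbon only, para to a diethylamino group, and that position is unchanged. Among the compounds with values here, nothing among the measured compounds shows what this exchange does in this assay, so the step from compound 1 to compound 3 is expected to be a 1.5-fold higher number from compound 1 to compound 3 (0.19 log units; within the scatter), a change estimated to stay near the scatter with no firm direction. On that basis compound 3 is expected to give about 20 nM, within a range of 5 nM to 80 nM.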

Compound 3, half-maximal inhibitory concentration: 13 nM
Compound 3: middle estimate off by 1.5-fold (0.19 log units), on the high side; the measured number falls inside the stated range.
By their numbers in this assay, from the lowest: compounds 1 and 3 (each within the scatter of the next); then compound 2.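

In this assay, within the data shown here, the exchange of methoxy for cyano on the aromatic carbon para to a diethylamino group gives no change at the digits printed from compound 1 to compound 3 (within the scatter), the first reading of any change at this position. On this pair, then, the assay does not separate the two groups, which match in their counts of heavy atoms and hydrogen-bond acceptors and differ in the cyano triple bond, so that bond and the loss of the methoxy oxygen leave no trace in the number here. No measurement of the properties of these groups accompanies the result, and the equal numbers therefore remain without an explanation.

The compounds shown leave open whether this carbon would accept groups of a different kind, such as an amine, a carboxylic acid or a longer chain like butoxy, with an equally small step. They also leave open whether the exchange of methoxy for cyano would read the same way with a different group on the aromatic ring of the anilino part, or with something other than the diethylamino group on the shared core.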